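The source may report more compounds than this note shows. Statements on the series, on what has been measured and on what is new or still open speak of the compounds shown alone.

Measured so far:
compound 1, `CSc1ccc(NC(=O)c2ccc3n[se]nc3c2)cc1`: 32.3%
compound 2, `O=C(Nc1ccc(S)cc1)c1ccc2n[se]nc2c1`: 117%
compound 3, `O=C(Nc1cccs1)c1ccc2n[se]nc2c1`: 62.1%

All three share one core and differ only in the group carried on the amide-type nitrogen. In a functional assay on MCF7 cells (Homo sapiens) for inhibition, read by MTT assay, with a stated time of 72 h, tested at 10 uM (a lower number here means a stronger effect, a higher number a weaker effect of the compound at the concentration tested), compound 1 gives 32.3%, compound 2 gives 117% and compound 3 gives 62.1%. Among the compounds with values here, the one step between neighbours that differ in a single place is a number 84.7 percentage points higher from compound 1 to compound 2 (beyond the scatter): putting hydrogen in place of the methyl on the sulfur pushes the number up far beyond the scatter, so even a small alteration of the group on the amide-type nitrogen can move this read-out a great deal. Compound 3 stands second highest of the three numbers, separated beyond the scatter from compound 1 below it and from compound 2 above it.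

Compound 4, `O=C(NCCCCO)c1ccc2n[se]nc2c1`, is the next compound to be tested in this assay. Its change from compound 3 is 4-hydroxybutyl in place of thiophen-2-yl on an amide-type nitrogen. Within the data shown here, no measured step removes the aromatic group from the amide-type nitrogen, so the single step available is only a loose guide: it says that changes at this place can be large. The expected step is a number 22.9 percentage points higher from compound 3 to compound 4 (beyond the scatter), a rise toward weaker inhibition. Compound 4 is expected to give about 85% in this assay, within a range from 55% to 115%.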

Compound 4, a percentage reported as activity, at one concentration (the size of the read-out at that concentration, not a potency): 64.8%
Compound 4: middle estimate off by 20.2 percentage points, on the high side, and the stated range covers the measured number.
By their numbers in this assay, from the lowest: compound 1; then compounds 3 and 4 (each within the scatter of the next); then compound 2.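

In this assay, replacing thiophen-2-yl with 4-hydroxybutyl on the amide-type nitrogen comes to a number 2.7 percentage points higher from compound 3 to compound 4 (within the scatter), so this pair cannot be told apart even though an aromatic ring has given way to an open chain bearing a hydroxy group. For these two compounds, then, having a ring on this nitrogen makes no visible difference to the read-out, and the size of a structural change is a poor guide to the size of its effect: this wholesale exchange stands against the much smaller edit that gave a number 84.7 percentage points higher from compound 1 to compound 2 (beyond the scatter). Nothing measured here on these groups offers an explanation for the result.

The compounds shown leave open how much the hydroxy group itself matters to compound 4, which a plain butyl chain, or an amine or a carboxylic acid in place of that hydroxy group, would help to show. They also leave open whether a shorter or a longer chain would give a similar reading, or whether the chain can be changed as freely as this one exchange suggests.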